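From 4-chlorophenyl to 2,3,4-trichlorophenyl: working notes

The source may hold more compounds than are shown below. What is called first, only, known or untested is meant among the compounds shown, and "the series" means these compounds.

Values in a functional assay on 2008 cells (Homo sapiens) for cytotoxicity, read by MTT assay, with a stated time of 68 h (a lower number here means a stronger inhibitor, a higher number a weaker inhibitor), follow.
- compound 1 `O=C(/C=C/c1cccc(OCc2ccccc2)c1)c1ccc([N+](=O)[O-])cc1` gives 49000 nM
- compound 2 `O=C(/C=C/c1cccc(OCc2ccccc2)c1)c1ccc(Cl)cc1` gives 20000 nM
- compound 3 `Cc1ccc(C(=O)/C=C/c2cccc(OCc3ccccc3)c2)cc1` gives 12900 nM

Compound 2 holds the middle place only loosely: the series shows a 1.6-fold lower number from compound 2 to compound 3 (0.19 log units; within the scatter) on one side and a 2.5-fold lower number from compound 1 to compound 2 (0.39 log units; beyond the scatter) on the other. Compound 4 `O=C(/C=C/c1cccc(OCc2ccccc2)c1)c1ccc(Cl)c(Cl)c1Cl` has 2,3,4-trichlorophenyl in place of 4-chlorophenyl on a carbonyl carbon. Among the compounds with values here, no measured compound carries more than one chlorine, so the steps bear only indirectly. The largest single-group replacement measured is a 3.8-fold lower number from compound 1 to compound 3 (0.58 log units; beyond the scatter) and sets the expected ceiling. The estimate in this assay is a 1.3-fold lower number from compound 2 to compound 4 (0.10 log units; within the scatter) as an expected step, with no firm direction. Compound 4 is expected at 16000 nM with an estimated range from 6000 nM to 40000 nM (still to be measured).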

Compound 4, half-maximal inhibitory concentration: 1500 nM
The estimate for compound 4 lay 11-fold (1.03 log units) above the measured number, outside the stated range (below it).
By their numbers in this assay, from the lowest: compound 4; then compounds 3 and 2 (each within the scatter of the next); then compound 1.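

In this assay the gain from adding chlorines to the ring on the carbonyl carbon is far larger than any seen among the earlier replacements, with a 13-fold lower number from compound 2 to compound 4 (1.12 log units; beyond the scatter). The 2,3,4-trichlorophenyl group also sets compound 4 clearly apart from the other two, with an 8.6-fold lower number from compound 3 to compound 4 (0.93 log units; beyond the scatter) and a 33-fold lower number from compound 1 to compound 4 (1.51 log units; beyond the scatter). Nothing at hand accounts for this gain.

The compounds shown leave open whether the gain needs all three chlorines or already appears with a dichlorophenyl group. Also open, going by these compounds, is whether a 2,3,4-trimethylphenyl group on the same carbonyl carbon would give a similar number.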